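The source may hold more compounds than are shown below. What is called first, only, known or untested is meant among the compounds shown, and "the series" means these compounds.

Measured so far:
compound 1, `CCCCCCCCC(CCCCCCCCC(=O)OC)SCC(=O)NCC(=O)OC`: 30800 nM
compound 2, `CCCCCCCCC(CCCCCCCCC(=O)OC)SCC(=O)N[C@@H](C)C(=O)OC`: 154000 nM

The two measured compounds share a long sulfur-linked chain ending in an amide, and differ only at the saturated chain carbon bound to the amide-type nitrogen and a carbonyl carbon. In a functional assay on DU-145 cells (Homo sapiens) for cytotoxicity, read by MTT assay (a lower number here means a stronger inhibitor, a higher number a weaker inhibitor), compound 1 gives 30800 nM, and compound 2 gives 154000 nM. Among the measured compounds shown here, compound 2 thus stands at the higher of the two numbers, the single step being a 5.0-fold higher number from compound 1 to compound 2 (0.70 log units; beyond the scatter).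

Compound 3, `CCCCCCCCC(CCCCCCCCC(=O)OC)SCC(=O)N[C@H](C(=O)OC)[C@@H](C)CC`, extends the same position further: sec-butyl in place of methyl on a saturated chain carbon bound to an amide-type nitrogen and a carbonyl carbon. For the measured compounds named here, the only step that bears on this change is the one already seen, a 5.0-fold higher number from compound 1 to compound 2 (0.70 log units; beyond the scatter), where a single carbon entering at this place pushed the number up by a modest but clear amount. Adding three more carbons at the same place is expected to continue in that direction, with the step from compound 2 to compound 3 estimated as a 2.3-fold higher number from compound 2 to compound 3 (0.36 log units; beyond the scatter). For compound 3 in this assay the expected value is therefore 350000 nM, with a likely range from 120000 nM to 1000000 nM.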

Compound 3, half-maximal inhibitory concentration: 19000 nM
Compound 3: middle estimate off by 18-fold (1.27 log units), on the high side; measured number outside the range, below it.
By their numbers in this assay, from the lowest: compounds 3 and 1 (each within the scatter of the next); then compound 2.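

Replacing methyl with sec-butyl in this assay gives an 8.1-fold lower number from compound 2 to compound 3 (0.91 log units; beyond the scatter), so the rise seen when methyl first appeared at this place does not continue as the group grows larger. Measured against hydrogen at the same place, sec-butyl gives a 1.6-fold lower number from compound 1 to compound 3 (0.21 log units; within the scatter), which means these two compounds cannot be told apart, while compound 2, with its methyl, is the weakest of the three, with steps beyond the scatter to both others. No available evidence explains why the smaller group gives the higher number while the larger one does not.

With only hydrogen, methyl and sec-butyl to compare, three points cannot show whether methyl is an isolated case or part of a broader trend, and groups of intermediate or greater size, such as isopropyl, a longer straight chain or benzyl, would help to settle this. Going by these compounds, it also remains open whether the result depends on the arrangement in space at the defined stereocentre of sec-butyl, or whether a carboxylic acid in place of the neighbouring methyl ester would alter the pattern.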